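The compounds below may be only part of what the source reports. "The series", "measured", "known", "first", "only" and "open" are said of these compounds alone.

Working notes on the series. Going by the values given here, compound 2 `CCNCCCc1c[nH]c2ccc(F)cc12` is the only member with a number in an assay on isolated protein for inhibition of Myeloperoxidase (Homo sapiens); on this read-out higher numbers stand for weaker inhibition and lower numbers for stronger inhibition: in this assay compound 2 gives 190 nM. Compound 1 `CCN(CC)Cc1c[nH]c2ccc(F)cc12` sits at a limit of this assay, and in this assay compound 1 gives > 1000 nM, as the limit of > 1000 nM in this assay, at which 1 of the 2 values shown sits, shows. Among the compounds with values here, the single measured step, an at least 5.2-fold lower number from compound 1 to compound 2 (0.72 log units; beyond the scatter), therefore has a floor but no exact size.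

Compound 3 `Fc1ccc2[nH]cc(CCCN3CCCC3)c2c1` carries the change (pyrrolidin-1-yl in place of ethylamino on a saturated chain carbon, three bonds along the chain from an aromatic carbon). It keeps the chain of compound 2 and alters only the group on that chain, whereas the step from compound 1 to compound 2 altered both the chain and the group at once, so that step bears on the present one only in part, and nothing measured separates the two parts. With the chain kept, the expected step of a 1.7-fold higher number from compound 2 to compound 3 (0.23 log units; within the scatter) is small, in the direction of a somewhat higher number, and may well stay within the scatter. The estimate for compound 3 in this assay is 320 nM, with a range from 100 nM to 1000 nM.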

Compound 3, half-maximal inhibitory concentration: 210 nM
Compound 3: the middle estimate sits 1.5-fold (0.18 log units) above what was measured, within the range that was stated.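

In this assay, the exchange of ethylamino for pyrrolidin-1-yl on a saturated chain carbon, three bonds along the chain from an aromatic carbon, gives a 1.1-fold higher number from compound 2 to compound 3 (0.04 log units; within the scatter), so the two values cannot be told apart. Going by these compounds alone, this is the first reading at this place with the chain held fixed, and it shows that, for this one pair, a group with 0 hydrogen-bond donors and a five-membered non-aromatic ring can stand in for a group with 1 hydrogen-bond donor and no ring without a separable difference in the read-out. Nothing measured in the series bears on a cause for this outcome.

The compounds shown leave open how much of an at least 5.2-fold lower number from compound 1 to compound 2 (0.72 log units; beyond the scatter) belongs to the chain and how much to the group, and diethylamino on the chain of compound 2 would separate the two parts. Also open, as far as these compounds go, is how far this similarity extends beyond ethylamino and pyrrolidin-1-yl, which morpholin-4-yl, a carboxylic acid or a longer chain at the same place would test.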